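Methyl on the fused ring: transfer from one core to another

The compounds below may be only part of what the source reports. "The series", "measured", "known", "first", "only" and "open" are said of these compounds alone.

Compound 1 `COCOc1ccccc1-c1cc2ccccc2c(=O)[nH]1` in a functional assay on HeLa cells (Homo sapiens) for cytotoxicity, read by sulforhodamine B assay (a lower number here means a stronger inhibitor, a higher number a weaker inhibitor), gives 620 nM. For the measured compounds named here, compound 2 `COCOc1ccccc1-c1cc2cc(C)ccc2c(=O)[nH]1` carries the change methyl in place of hydrogen on an aromatic carbon relative to compound 1, and in this assay compound 2 gives 170 nM; the step of a 3.6-fold lower number from compound 1 to compound 2 (0.56 log units; beyond the scatter) is the only measured instance of this change. Compound 3 `C=COc1ccccc1-c1c(Br)c2ccccc2c(=O)n1Cc1ccc(OC)cc1` rests on a different core; how the two cores differ is not broken down here. In this assay compound 3 gives 36500 nM, the highest of the three numbers and beyond the scatter from both compound 1 and compound 2.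

Going by the values given here, compound 4 `C=COc1ccccc1-c1c(Br)c2cc(C)ccc2c(=O)n1Cc1ccc(OC)cc1` differs from compound 3 by methyl in place of hydrogen on an aromatic carbon, the same change as the one made from compound 1 to compound 2, at a place described in the same words. The question is whether the step carries over onto the core of compound 3. Among the compounds with values here, with only one measured instance, and that on another core, the expected step is set somewhat smaller than the step seen from compound 1 to compound 2. The estimate for compound 4 means an expected step of a 2.6-fold lower number from compound 3 to compound 4 (0.42 log units; beyond the scatter). In this assay compound 4 is therefore expected to come to 14000 nM, with a range of 5000 nM to 40000 nM.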

Compound 4, half-maximal inhibitory concentration: 14800 nM
Compound 4: middle estimate off by 1.1-fold (0.02 log units), on the low side; the measured number falls inside the stated range.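

In this assay methyl in place of hydrogen on an aromatic carbon gives a 2.5-fold lower number from compound 3 to compound 4 (0.39 log units; beyond the scatter), so the change keeps its direction on the core of compound 3. The two steps also agree in size: the same change on two cores in this assay, a 3.6-fold lower number (0.56 log units; beyond the scatter) from compound 1 to compound 2 and a 2.5-fold lower number (0.39 log units; beyond the scatter) from compound 3 to compound 4, 1.5-fold (0.17 log units) apart, within the scatter of two such steps

This shows that the change carries over between these two cores, but it rests on just two pairs, so it sets no rule for other cores in the series and does not explain why the number falls.

Among the compounds shown, methyl is the only group that replaces hydrogen at this place, so it remains open whether a longer chain, an amine or a carboxylic acid on the same aromatic carbon would shift the number in the same direction on both cores. Also open, as far as these compounds go, is whether methyl on another aromatic carbon of that ring would give a matching step on the two cores.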